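This account rests on a few compounds, and the source may have more. Where it says the series, first, only, none or still open, it means among the compounds named here.

Of the compounds shown here, three built on a shared core have been measured in an assay on isolated protein for displacement of a labelled ligand from 5-hydroxytryptamine receptor 6 (Homo sapiens); a lower number here means a stronger inhibitor, a higher number a weaker inhibitor. Compound 1 `CNCC1CCCc2cc(S(=O)(=O)c3ccccc3)ccc21` gives 0.316 nM. Compound 2 `CS(=O)(=O)c1cccc(S(=O)(=O)c2ccc3c(c2)CCC[C@H]3CN)c1` gives 3.98 nM. Compound 3 `O=C(NC[C@@H]1CCCc2cc(S(=O)(=O)c3cccc(F)c3)ccc21)c1ccc[nH]1` gives 5.01 nM. Compound 3 thus carries the highest number of the three, though its gap to compound 2 lies within the scatter, while its gap to compound 1 lies beyond it. Compound 4 `NS(=O)(=O)NC[C@@H]1CCCc2cc(S(=O)(=O)c3cccc(F)c3)ccc21` differs from compound 3 in one place: sulfamoyl in place of (1H-pyrrol-2-yl)carbonyl on an amine nitrogen. Among the measured compounds shown here, no measured pair shows what this exchange does, so the expectation rests on compound 3 alone. In this assay the number for compound 4 is expected to move only a little, with a 2.0-fold higher number from compound 3 to compound 4 (0.30 log units; within the scatter) pointing to a slightly higher number near the edge of the scatter. Compound 4 is estimated at 10 nM, between 3 nM and 40 nM.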

Compound 4, inhibition constant: 0.126 nM
For compound 4 the middle estimate is 79-fold (1.90 log units) above the measured one; the measured number lies below the stated range.
By their numbers in this assay, from the lowest: compound 4; then compound 1; then compounds 2 and 3 (each within the scatter of the next).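

In this assay, the step at this amine nitrogen is a 40-fold lower number from compound 3 to compound 4 (1.60 log units; beyond the scatter) and lies beyond the scatter, so the group carried there can strongly change the number. The lower number comes with sulfamoyl, which has no ring and 4 heavy atoms, in place of (1H-pyrrol-2-yl)carbonyl, which has a five-membered aromatic ring and 7 heavy atoms. No measurement given here accounts for this step. Still open, going by these compounds, is whether the step depends on the sulfamoyl group as a whole or only on losing the pyrrole ring. An acetyl or methylsulfonyl group on the same nitrogen would help separate these two readings.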